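Benzyl swap on the pyrazine carboxamide: compound 3 to compound 4

The source may hold more compounds than are shown below. What is called first, only, known or untested is meant among the compounds shown, and "the series" means these compounds.

Measured so far:
compound 1 `CCc1ccc(Cn2c(CCc3ccccc3)nnc2[C@H](NC(=O)c2ccccn2)c2c[nH]c3ccccc23)cc1` — 513 nM
compound 2 `CCc1ccc(Cn2c(CCc3ccccc3)nnc2[C@H](NC(=O)Cc2cccnc2)c2c[nH]c3ccccc23)cc1` — "not determined" (no result reported)
compound 3 `COc1ccc(Cn2c(CCc3ccccc3)nnc2[C@H](NC(=O)c2cnccn2)c2c[nH]c3ccccc23)c(OC)c1` — 24 nM

In a functional assay on CHO cells for antagonist activity at growth hormone secretagogue receptor type 1 (Homo sapiens) (a higher number here means a weaker inhibitor, a lower number a stronger inhibitor), compound 3 gives 24 nM, the lowest of the two numbers in hand. Its nearest neighbour is compound 1, which in this assay gives 513 nM, a higher number, and that gap lies beyond the scatter. Compound 2 has no result in this assay, so it adds nothing to the comparison.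

Compound 4 `CCc1ccc(Cn2c(CCc3ccccc3)nnc2[C@H](NC(=O)c2cnccn2)c2c[nH]c3ccccc23)cc1` differs from compound 3 in one place: 4-ethylphenyl in place of 2,4-dimethoxyphenyl on a saturated chain carbon bound to an aromatic nitrogen. Going by the values given here, compound 4 shares its 4-ethylbenzyl group with compound 1 and its pyrazine carboxamide with compound 3, so no single measured step isolates the benzyl change on its own; the two measured values differ at both places at once.

The expectation is that the step from compound 3 to compound 4 goes toward a higher number, a 6.3-fold higher number from compound 3 to compound 4 (0.80 log units; beyond the scatter), partly because compound 1 with the same 4-ethylbenzyl gives 513 nM. Compound 4 is therefore estimated at 150 nM, in the range 40 nM to 600 nM.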

Compound 4, antagonist equilibrium constant: 76 nM
For compound 4 the middle estimate is 2.0-fold (0.30 log units) above the measured one, and the stated range covers the measured number.
By their numbers in this assay, from the lowest: compound 3; then compound 4; then compound 1.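

The benzyl position now has a single-place reading in this assay: 4-ethylphenyl in place of 2,4-dimethoxyphenyl gives a 3.2-fold higher number from compound 3 to compound 4 (0.50 log units; beyond the scatter) on the pyrazine carboxamide. The carbonyl side has one too, with pyrazin-2-yl in place of pyridin-2-yl giving a 6.8-fold lower number from compound 1 to compound 4 (0.83 log units; beyond the scatter) on the 4-ethylbenzyl series, so each of these two places alone moves the number beyond the scatter. No data in hand give a reason for either step.

Going by these compounds alone, whether the two changes add up stays open, since one pair holds the benzyl group fixed and the other the carboxamide, and no compound joins 2,4-dimethoxybenzyl to the pyridin-2-yl carboxamide. Also open, going by these compounds, is how a benzyl group with a single methoxy, or with a carboxylic acid or an amine, would read at this position.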